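This account rests on a few compounds, and the source may have more. Where it says the series, first, only, none or still open, it means among the compounds named here.

Working notes on the series. Compound 3 `N#CCCSNC(=O)[C@@H](CCC(F)(F)F)N(Cc1ccc(-c2ncon2)cc1F)S(=O)(=O)c1ccc(Cl)cc1` stands at the top of what has been seen: in a physicochemical assay for pharmacokinetics, at pH 4, tested at 100 ug/mL (a lower number here means that the compound disappears faster, a higher number that the compound lasts longer), compound 3 gives > 500 h, which is a limit of the assay and not a number. Compound 1 `NCCSNC(=O)[C@@H](CCC(F)(F)F)N(Cc1ccc(-c2ncon2)cc1F)S(=O)(=O)c1ccc(Cl)cc1` gives > 500 h, likewise a limit. Compound 2 `N[C@@H](CSNC(=O)[C@@H](CCC(F)(F)F)N(Cc1ccc(-c2ncon2)cc1F)S(=O)(=O)c1ccc(Cl)cc1)C(=O)O` gives 418 h. Among the steps, an at least 1.1-fold lower number from compound 1 to compound 2 (0.07 log units; that floor lies within the scatter) and an at least 1.1-fold higher number from compound 2 to compound 3 (0.07 log units; that floor lies within the scatter) are readable, while a step that the two limits leave unreadable from compound 1 to compound 3, because of the limit of > 500 h in this assay, at which 2 of the 3 values shown sit. Compound 4 `CCOC(=O)[C@@H](N)CSNC(=O)[C@@H](CCC(F)(F)F)N(Cc1ccc(-c2ncon2)cc1F)S(=O)(=O)c1ccc(Cl)cc1` differs from compound 3 in that (amino(ethoxycarbonyl)methyl in place of cyanomethyl on a saturated chain carbon bound to a sulfur). The nearest measured change is the reverse of the step from compound 2 to compound 3, which stayed within scatter, so the step of an at least 1.1-fold lower number from compound 3 to compound 4 (0.05 log units; that floor lies within the scatter) is expected to be small or none beyond scatter. Compound 4 is estimated at 440 h, within 250 h to 600 h.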

Compound 4, half-life: 258 h
Compound 4: middle estimate off by 1.7-fold (0.23 log units), on the high side, and the stated range covers the measured number.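

In this assay, an at least 1.9-fold lower number from compound 3 to compound 4 (0.28 log units; that floor lies within the scatter) and an at least 1.9-fold lower number from compound 1 to compound 4 (0.28 log units; that floor lies within the scatter) are floors only, because compound 3 and compound 1 both sit at a limit: the limit of > 500 h in this assay, at which 2 of the 4 values shown sit. Ethyl on the oxygen next to a carbonyl group gives a 1.6-fold lower number from compound 2 to compound 4 (0.21 log units; within the scatter), so the ethyl ester and the carboxylic acid are not separated at this position. No change printed at this position lies beyond the scatter. From the compounds shown here alone, whether a methyl ester or a primary amide in place of ethoxycarbonyl would read the same stays open. Going by these compounds, the true size of the steps starting from the two limits also stays open.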